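The compounds below may be only part of what the source reports. "The series", "measured", "known", "first", "only" and "open" are said of these compounds alone.

Compounds measured in an ADME assay on the whole organism with Oryza sativa as the target, tested at 1 uM; on this read-out higher numbers stand for a weaker effect at the one concentration tested and lower numbers for a stronger effect:
compound 1, `Cc1ccc(NC(=O)N[C@H](C)c2ccccc2)cc1`, gives 98%;
compound 2, `C[C@@H](NC(=O)Nc1ccc(F)cc1)c1ccccc1`, gives 96%.

Compound 1 and compound 2 share one core and differ only in one group on an aromatic carbon; the change was a number 2 percentage points lower from compound 1 to compound 2 (within the scatter), so the two values sit within the scatter of each other and neither can be called stronger or weaker. Compound 3, `C[C@@H](NC(=O)Nc1ccc(Br)cc1)c1ccccc1`, is not yet measured. It differs from compound 2 by bromo in place of fluoro on an aromatic carbon. Within the data shown here, the only measured step that bears on this change is the one at the same place, from methyl to fluoro, which was a number 2 percentage points lower from compound 1 to compound 2 (within the scatter); a further swap of one halogen for another at that place is therefore expected to give no step beyond the scatter in this assay . The expected step is no change at the digits printed from compound 2 to compound 3 (within the scatter). Compound 3 is accordingly estimated to give 96%, within a range from 87% to 100%.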

Compound 3, a percentage reported as activity, at one concentration (the size of the read-out at that concentration, not a potency): 95%
Compound 3: middle estimate off by 1 percentage points, on the high side; low and high end bracket the measured number.
By their numbers in this assay, from the lowest: compounds 3, 2 and 1 (each within the scatter of the next).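

In this assay, the group at this aromatic carbon, para to a large group, is now bromo, which gives a number 1 percentage points lower from compound 2 to compound 3 (within the scatter) and a number 3 percentage points lower from compound 1 to compound 3 (within the scatter). Among these compounds, three different groups have now been read at this one place, methyl, fluoro and bromo, and all three values lie within the scatter of each other, whereas the earlier pair covered only two groups and one halogen. No measurement at hand offers a reason for this sameness.

Going by these compounds, whether a group of another kind at this place, such as an amine, a carboxylic acid or a longer chain, would give a number beyond the scatter remains open. The compounds shown differ only at this one place, so what a change elsewhere on the shared core would do is also open.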